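Adding one methyl to compound 2

The source may report more compounds than this note shows. Statements on the series, on what has been measured and on what is new or still open speak of the compounds shown alone.

In a functional assay on the whole organism (Abdomen) with Mus musculus as the target (a lower number here means that less compound is needed, a higher number that more compound is needed for the effect), compound 1 `CCc1nc(Cc2c[nH]cn2)c(CC)o1` gives 2.8 mg/kg and compound 3 `CC(C)c1nc(Cc2c[nH]cn2)c(C(C)C)s1` gives 23.8 mg/kg as measured doses. Compound 2 `Cc1nc(Cc2c[nH]cn2)c(C)s1` is reported as > 30 mg/kg and this is a limit of the assay, not a number. Compound 2 therefore stands at the limit of > 30 mg/kg in this assay, at which 1 of the 3 values shown sits, and offers no exact starting figure.

Compound 4 `CCc1nc(Cc2c[nH]cn2)c(C)s1` differs from compound 2 in one place methyl in place of hydrogen on a saturated chain carbon bound to an aromatic carbon and in words this is methyl in place of hydrogen on a saturated chain carbon bound to an aromatic carbon, so that methyl becomes ethyl.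

Within the data shown here, no measured pair shows this change alone, so its size has to be judged from less close relatives. Compound 1 with its ethyl chains at 2.8 mg/kg and compound 3 with its isopropyl chains at 23.8 mg/kg both give numbers, although they differ from compound 2 in more than one place. A moderate move towards a lower dose is therefore expected, with little confidence in its size. The estimated change is an at least 1.6-fold lower number from compound 2 to compound 4 (0.22 log units; that floor lies within the scatter) and it points to less compound being needed. For compound 4 the expected dose is 18 mg/kg with an estimated range from 6 mg/kg to 50 mg/kg and a report of only a limit remains possible.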

Compound 4, dose for half-maximal effect: > 30 mg/kg
Compound 4 was reported as a limit; the forecaster's own chance of this, stated with the estimate: 35%; middle value at least 1.6-fold (0.22 log units) from the limit.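

In this assay neither compound 2 nor compound 4 gives a number, so no step between them can be read; each stands at a limit of the assay, not at a measured dose: the limit of > 30 mg/kg in this assay, at which 2 of the 4 values shown sit.

The compounds shown leave open whether turning methyl into ethyl at this place changes the dose needed at all, and by how much.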